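Extending the Amino Acid Side Chain of Compound 3

The source may hold more compounds than are shown below. What is called first, only, known or untested is meant among the compounds shown, and "the series" means these compounds.

Compound 3 `NC(=O)C[C@H](NC(=O)CN(c1nc(Cl)nc2c1ncn2C1CCCCO1)C1CC1)C(=O)OCc1ccccc1` stands highest of the three compounds measured in a functional assay on the whole organism with Mus musculus as the target, with a stated time of 90 min, at a dose of 25 umol/kg by the oral route (a lower number here means a weaker effect, a higher number a stronger effect of the compound at the dose given), where compound 3 gives 35%. Within the data shown here, compound 1 `CCOC(=O)CN(c1nc(Cl)nc2c1ncn2C1CCCCO1)C1CC1` gives 13%, and compound 2 `O=C(O)CN(c1nc(Cl)nc2c1ncn2C1CCCCO1)C1CC1` gives 8.22%; the only measured step between them, a number 4.8 percentage points lower from compound 1 to compound 2 (within the scatter), lies within the scatter. Compound 4 `CC(C)(C)OC(=O)NCCCC[C@H](NC(=O)CN(c1nc(Cl)nc2c1ncn2C1CCCCO1)C1CC1)C(=O)OCc1ccccc1` differs from compound 3 by 3-((tert-butoxycarbonyl)amino)propyl in place of carbamoyl on a saturated chain carbon, two bonds along the chain from an amide-type nitrogen and a carbonyl carbon. Among the measured compounds shown here, no measured step touches this place: the one step known concerns hydrogen in place of ethyl on an oxygen next to a carbonyl group, so it gives no guide to the size or direction of the change on the chain. The step of a number 5 percentage points lower from compound 3 to compound 4 (within the scatter) is therefore expected to be small, with a wide range of uncertainty. Compound 4 is estimated at 30%, between 10% and 55%.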

Compound 4, a percentage reported as activity, at one dose (the size of the read-out at that dose, not a potency): 32.9%
Compound 4: the middle estimate sits 2.9 percentage points below what was measured, within the range that was stated.
By their numbers in this assay, from the lowest: compounds 2 and 1 (each within the scatter of the next); then compounds 4 and 3 (each within the scatter of the next).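

At this place on the saturated chain carbon, two bonds along the chain from an amide-type nitrogen and a carbonyl carbon, the change gives a number 2.1 percentage points lower from compound 3 to compound 4 (within the scatter) in this assay. Thus 3-((tert-butoxycarbonyl)amino)propyl, with 11 heavy atoms in place of the 3 of carbamoyl, leaves the read-out at this dose within the scatter. No measured evidence bears on why this is so. Still open, going by these compounds, is how a free amine or a carboxylic acid at the end of this chain would read, and whether a shorter or longer chain would read the same.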